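This account rests on a few compounds, and the source may have more. Where it says the series, first, only, none or still open, it means among the compounds named here.

Compound 1 `CCN(CC)Cc1c(O)c([C@H]2CCN(C)C[C@H]2O)c2oc(C)cc(=O)c2c1O` gives 47%
Compound 2 `CN1CC[C@H](c2c(O)cc(O)c3c(=O)cc(/C=C/c4ccc(Cl)cc4)oc23)[C@H](O)C1` gives 58%

In a functional assay on HL-60 cells (Homo sapiens) for inhibition, read by MTT assay, with a stated time of 48 h, tested at 10 uM (on this read-out higher numbers stand for more inhibition of growth at the one concentration tested and lower numbers for less inhibition of growth), compound 2 stands highest of the two numbers, and its gap to compound 1 lies beyond the scatter. Compound 3 `CN1CC[C@H](c2c(O)cc(O)c3c(=O)cc(/C=C/c4cccc(F)c4)oc23)[C@H](O)C1` differs from compound 2 as follows: 3-fluorophenyl in place of 4-chlorophenyl on a double-bonded chain carbon bound to a double-bonded chain carbon. Among the compounds with values here, no measured step covers this change, so the only guide is compound 2 at 58%. The expected result in this assay is a slight fall that stays within the scatter, estimated as a number 6 percentage points lower from compound 2 to compound 3 (within the scatter). Compound 3 is expected at 52%, with an estimated range from 36% to 68%.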

Compound 3, percent growth inhibition at one concentration: 60%
Beside the measured number, compound 3's estimate is 8 percentage points below it; the measured number falls inside the stated range.
By their numbers in this assay, from the lowest: compound 1; then compounds 2 and 3 (each within the scatter of the next).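

In this assay, 3-fluorophenyl in place of 4-chlorophenyl on a double-bonded chain carbon bound to a double-bonded chain carbon gives a number 2 percentage points higher from compound 2 to compound 3 (within the scatter). This position therefore accepts this exchange without a readable difference in growth inhibition. No available finding accounts for this result.

The halogen and its printed ring position change together in this single step, and their separate contributions remain unresolved. Also open, from the compounds shown here alone, is how this position would read with an unsubstituted phenyl, a methoxyphenyl or an aminophenyl group.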